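The compounds below may be only part of what the source reports. "The series", "measured", "known", "first", "only" and "open" are said of these compounds alone.

Of the compounds shown here, three have so far been measured in a functional assay on CHO-K1 cells with Glucose-dependent insulinotropic receptor (Homo sapiens) as the target, read by a luciferase reporter, with a stated time of 5 h; a higher number here means a larger maximal response, a lower number a smaller maximal response. Compound 1 `CC(C)OC(=O)N1CCC(Oc2ncnc3c2CCN3c2ccc(-c3cccn3C)cc2F)CC1` gives 44%. Compound 2 `COC(=O)N1CCC(Oc2ncnc3c2CCN3c2ccc(S(C)(=O)=O)cc2F)CC1` gives 119%, and compound 3 `CCOC(=O)N1CCC(Oc2ncnc3c2CCN3c2ccc(S(C)(=O)=O)cc2F)CC1` gives 135%. Compound 3 stands highest of the three numbers; compound 2 is nearest to it, separated by the step of a number 16 percentage points higher from compound 2 to compound 3 (beyond the scatter), while compound 1 lies furthest below, its value far beyond the scatter from that of compound 3.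

Compound 4 `CN(C)S(=O)(=O)N1CCC(Oc2ncnc3c2CCN3c2ccc(S(C)(=O)=O)cc2F)CC1` differs from compound 3 in one place: dimethylsulfamoyl in place of ethoxycarbonyl on an amine nitrogen in a ring. Going by the values given here, the only measured step that touches this position is a number 16 percentage points higher from compound 2 to compound 3 (beyond the scatter), a modest change that lengthened the chain on the oxygen of the carbamate while keeping the carbamate itself. Among the compounds with values here, no measured pair exchanges the whole ethoxycarbonyl for another group on the ring nitrogen, so the present change goes further than anything the data cover. Within the data shown here, the small size of the one related step suggests that the response is not very sensitive to what sits on this nitrogen, and a step in this assay no larger than modest, in either direction, is expected. For compound 4 the estimated value is 120%, with a range from 90% to 150%, which means an expected step of a number 15 percentage points lower from compound 3 to compound 4 (beyond the scatter).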

Compound 4, largest response reached (reported as percent of maximum), in percent of the reference or control that the assay uses: 68%
The estimate for compound 4 lay 52 percentage points above the measured number; the measured number lies below the stated range.
By their numbers in this assay, from the lowest: compound 1; then compound 4; then compound 2; then compound 3.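

In this assay, the group on the amine nitrogen in the ring proves far more consequential than the earlier pair suggested: dimethylsulfamoyl in place of ethoxycarbonyl brings a number 67 percentage points lower from compound 3 to compound 4 (beyond the scatter), and the same group in place of methoxycarbonyl brings a number 51 percentage points lower from compound 2 to compound 4 (beyond the scatter), both large, whereas the change within the carbamate gave only a number 16 percentage points higher from compound 2 to compound 3 (beyond the scatter). Among these three compounds, which share everything except this group, the maximal response therefore shifts modestly when the chain on the carbamate oxygen changes and much more when the whole carbonyl group gives way to the sulfamoyl group. Nothing given here accounts for the size of this drop.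

The compounds shown leave open whether the loss follows from the sulfonyl part or from the dimethylamino part of the new group, a question that methanesulfonyl or dimethylcarbamoyl on the same nitrogen would help to separate. They also leave open how far the rise seen with the longer chain extends, for instance to propoxycarbonyl or to isopropoxycarbonyl on the core of compound 3.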